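Removing the phenylsulfonyl group: compound 3 to compound 4

This account rests on a few compounds, and the source may have more. Where it says the series, first, only, none or still open, it means among the compounds named here.

Measured so far:
compound 1 `COc1ccc(C(=O)Nc2cccc3c2N(S(=O)(=O)c2ccc(OC)cc2)CC3)cc1` gives 1600 nM in a functional assay on MKN-45 cells (Homo sapiens) for cytotoxicity; a lower number here means a stronger inhibitor, a higher number a weaker inhibitor
compound 2 `COc1ccc(S(=O)(=O)N2CCc3cccc(NS(=O)(=O)c4ccc(F)cc4)c32)cc1` gives 890 nM in this assay
compound 3 `COc1ccc(S(=O)(=O)N2CCc3cccc(NS(=O)(=O)c4ccccc4)c32)cc1` gives 562 nM in this assay

Compound 3 shows the lowest number of the three, but its gap to compound 2 is within the scatter a 1.6-fold lower number from compound 2 to compound 3 (0.20 log units; within the scatter); only against compound 1 is it clearly apart a 2.8-fold lower number from compound 1 to compound 3 (0.45 log units; beyond the scatter).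

Compound 4 `COc1ccc(S(=O)(=O)N2CCc3cccc(N)c32)cc1` differs from compound 3 by hydrogen in place of phenylsulfonyl on a nitrogen on an aromatic ring. Going by the values given here, no measured step matches this: a 1.8-fold lower number from compound 1 to compound 2 (0.25 log units; within the scatter) and a 2.8-fold lower number from compound 1 to compound 3 (0.45 log units; beyond the scatter) swap one cap on that nitrogen for another, and a 1.6-fold lower number from compound 2 to compound 3 (0.20 log units; within the scatter) drops only a fluoro. Loss of the whole group is untested here, so a weaker result is expected, an 8.9-fold higher number from compound 3 to compound 4 (0.95 log units; beyond the scatter). Compound 4 is estimated at 5000 nM, range 1500 nM to 20000 nM.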

Compound 4, half-maximal inhibitory concentration: 1200 nM
Compound 4: middle estimate off by 4.2-fold (0.62 log units), on the high side; measured number outside the range, below it.
By their numbers in this assay, from the lowest: compounds 3, 2, 4 and 1 (each within the scatter of the next, the first and the last beyond it).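

In this assay, taking the cap off this nitrogen gives a 2.1-fold higher number from compound 3 to compound 4 (0.33 log units; beyond the scatter) and so only a modest change: the phenylsulfonyl group is not essential for a response at this level. The free amino compound cannot be separated from the other capped compounds, with a 1.3-fold higher number from compound 2 to compound 4 (0.13 log units; within the scatter) and a 1.3-fold lower number from compound 1 to compound 4 (0.12 log units; within the scatter) both inside the scatter. Nothing measured here explains the result.

Open, on these data alone, is whether a smaller cap on this nitrogen, such as acetyl or methylsulfonyl, would differ from the amino compound. Also open, as far as these compounds go, is how a dimethylamino group would read here.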